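The source may hold more compounds than are shown below. What is called first, only, known or untested is meant among the compounds shown, and "the series" means these compounds.

In a functional assay on NCI-H460 cells (Homo sapiens) for cytotoxicity, read by MTT assay, with a stated time of 72 h (on this read-out higher numbers stand for weaker inhibition and lower numbers for stronger inhibition), compound 2 (`COc1ccc([C@H](CC(=O)N[C@@H](CC(C)C)B(O)O)NC(=O)c2ccccc2)cc1`) gives 25300 nM, and compound 1 (`COc1ccc(C(CC(=O)N[C@@H](CC(C)C)B(O)O)NC(=O)c2ccccc2)cc1`) gives 36000 nM, so the two lie within the scatter of each other. Compound 3 (`COc1ccc([C@@H](CC(=O)N[C@@H](CC(C)C)B(O)O)NC(=O)c2ccccc2)cc1`) differs from compound 2 only in configuration: the two compounds have the same atoms and bonds and differ only in configuration as drawn: 1 of 2 stereo elements differ; a stereocentre at a saturated chain carbon is drawn S in compound 2 and R in compound 3. It has the same atoms and bonds, with the stereocentre at a saturated chain carbon drawn S in compound 2 and R in compound 3.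

Within the data shown here, one measured step bears on this carbon: a 1.4-fold lower number from compound 1 to compound 2 (0.15 log units; within the scatter), where compound 1 has no drawn configuration. As that step stays within the scatter, no change beyond the scatter is expected in this assay, and any drift is expected towards a somewhat higher number. The expected step is a 1.5-fold higher number from compound 2 to compound 3 (0.18 log units; within the scatter), which would remain within the scatter. For compound 3 the estimated value is 38000 nM, with an expected range from 17000 nM to 85000 nM.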

Compound 3, half-maximal inhibitory concentration: 14600 nM
Beside the measured number, compound 3's estimate is 2.6-fold (0.42 log units) above it; the whole stated range lies above it.
By their numbers in this assay, from the lowest: compounds 3, 2 and 1 (each within the scatter of the next, the first and the last beyond it).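

Inverting the saturated chain carbon from S to R in this assay gives a 1.7-fold lower number from compound 2 to compound 3 (0.24 log units; within the scatter), so with both drawn configurations now in hand, this stereocentre shows no change beyond the scatter: the fact that compounds 2 and 3 differ only in the configuration as drawn

Only the R form separates from the compound without a drawn configuration, with a 2.5-fold lower number from compound 1 to compound 3 (0.39 log units; beyond the scatter), a modest step that compound 2 does not match: the fact that one of compounds 1 and 3 is drawn with a defined configuration and the other without, at the place where they differ

The composition of compound 1 at this carbon is not stated, so this step cannot be read as a clean measure of the R configuration.

Going by these compounds, whether the two configurations stay this close with a carboxylic acid in place of the boronic acid, or with a longer chain in place of the isobutyl group, remains open. On these data alone, the second stereocentre is drawn the same in all three compounds, so its inversion also remains open.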